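This account rests on a few compounds, and the source may have more. Where it says the series, first, only, none or still open, it means among the compounds named here.

Compound 1, `CN(O)C(=O)c1ccccn1`: > 1000000 nM
Compound 2, `CN(O)C(=O)c1cccc[n+]1[O-]`: > 1000000 nM

Both numbers come from an ADME assay on Huh-7 cells (Homo sapiens) for cytotoxicity, read by MTT assay, with a stated time of 72 h; a higher number here means that more compound is tolerated, a lower number that less compound is tolerated. The value for compound 1 is a limit of that assay, not a measured number. The value for compound 2 is likewise a limit and not a number. On the numbers shown, compound 2 stands at the upper edge of what this assay reports, (the limit of > 1000000 nM in this assay, at which 2 of the 2 values shown sit). Compound 1 and compound 2 differ from each other in more than one place, and no single step between measured compounds is shown.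

Compound 3, `O=C(NO)c1cccc[n+]1[O-]`, has not yet been tested in this assay. It differs from compound 2 in one place: hydrogen in place of methyl on an amide-type nitrogen. Cut one bond further out, the change reads hydroxy(methyl)amino to hydroxyamino.

Going by the values given here, with no measured step to lean on, the change is expected to shift this assay little, if at all, beyond the usual scatter. The step from compound 2 to compound 3 is estimated at a number no higher from compound 2 to compound 3 (the limit leaves the size open). Compound 3 is therefore expected to sit at about 1000000 nM, somewhere from 300000 nM to 3000000 nM, most likely reported once more as a limit rather than a number.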

Compound 3, half-maximal cytotoxic concentration: 900000 nM
Compound 3: the middle estimate sits 1.1-fold (0.05 log units) above what was measured; low and high end bracket the measured number.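

Going by these compounds alone, compound 3 gives the first actual number in this assay, so this position now has a measured reading against which further changes can be set. Compound 2 has only a limit in this test, > 1000000 nM, and not a number. Hydrogen in place of methyl on the amide-type nitrogen gives an at least 1.1-fold lower number from compound 2 to compound 3 (0.04 log units; that floor lies within the scatter), and this figure is only a floor, so the change cannot be called either silent or large because one end of the step is a limit: the limit of > 1000000 nM in this assay, at which 2 of the 3 values shown sit.

On these data alone, how far the tolerated concentration would move with an ethyl group or a longer chain on that amide-type nitrogen remains open, as does the result of a primary amine or a carboxylic acid in place of the hydroxyamino group. As far as these compounds go, whether hydroxyamino has the same effect on the core of compound 1 also remains unknown, since that comparison would need a number at each end of the step rather than a limit.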